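The compounds below may be only part of what the source reports. "The series", "measured", "known", "first", "only" and "open" are said of these compounds alone.

Measured compounds:
- compound 1 `COc1ccc(-c2cc(-c3ccccc3O)nc(N)n2)cc1` — 92200 nM
- compound 2 `COc1cccc(-c2cc(-c3ccccc3O)nc(N)n2)c1` — > 78300 nM (a limit of the assay)

Both compounds share the same core and differ only in where the methoxy sits. In an ADME assay on MT4 cells (Homo sapiens) for cytotoxicity, read by MTT assay, with a stated time of 5 days (a higher number here means that more compound is tolerated, a lower number that less compound is tolerated), compound 1 gives 92200 nM. For compound 2 only > 78300 nM is known, and this is a limit of the assay, not a number. Compound 2 thus stands at the limit of > 78300 nM in this assay, at which 1 of the 2 values shown sits, rather than at a measured point. Compound 3 `COc1ccc(-c2cc(-c3ccccc3O)nc(N)n2)cc1OC` has not been measured in this assay. It differs from compound 2 by methoxy in place of hydrogen on an aromatic carbon. Among the measured compounds shown here, no step between measured compounds is available to set the size of this change, so in this assay no step beyond the usual scatter is expected in either direction. Compound 3 is expected to give about 85000 nM (range 30000 nM to 200000 nM), an expected step that the limit leaves unreadable from compound 2 to compound 3.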

Compound 3, half-maximal cytotoxic concentration: 7360 nM
Compound 3: the middle estimate sits 12-fold (1.06 log units) above what was measured, and the stated range ends above it.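

In this assay a second methoxy on the same ring makes a large difference: set on an aromatic carbon ortho to a methoxy group and para to a large group, it gives an at least 10-fold lower number from compound 2 to compound 3 (1.02 log units; beyond the scatter) and so marks a compound of which less is tolerated. The figure for compound 2 is a limit of the assay, not a number: the limit of > 78300 nM in this assay, at which 1 of the 3 values shown sits. Methoxy in place of hydrogen also gives a 13-fold lower number from compound 1 to compound 3 (1.10 log units; beyond the scatter) between two measured values, so the lower tolerance of compound 3 does not rest on the limit alone.

Still open, going by these compounds, is whether another group at this place, such as a hydroxyl, an amine or a longer ether chain, would lower the number as well. The compounds shown also leave open whether two methoxy groups elsewhere on the ring would do the same.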